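A few compounds are considered here, and "the series" means these few. Any claim that something is new, unique, unknown or untested is made for them only; others in the source may bear on it.

Compound 1 `CCn1c(=O)/c(=C2\Sc3ccc(OC)cc3N2C)s/c1=C\c1ccncc1Nc1ccccc1C` gives 410 nM in a functional assay on CWR22R cells (Homo sapiens) for inhibition; a higher number here means a weaker inhibitor, a lower number a stronger inhibitor.
Compound 2 `CCn1c(=O)/c(=C2\Sc3ccc(C)cc3N2C)s/c1=C\c1ccncc1Nc1ccccc1C` gives 480 nM in this assay.
Compound 3 `CCn1c(=O)/c(=C2\Sc3ccc(C)cc3N2C)s/c1=C\c1ccncc1Nc1ccccc1F` gives 150 nM in this assay.

Compound 4 `CCn1c(=O)/c(=C2\Sc3ccc(OC)cc3N2C)s/c1=C\c1ccncc1Nc1ccccc1F` has not yet been measured in this assay. It differs from compound 3 by methoxy in place of methyl on an aromatic carbon. The same change is already measured once, from compound 2 to compound 1 as methoxy in place of methyl on an aromatic carbon, where it gave a 1.2-fold lower number from compound 2 to compound 1 (0.07 log units; within the scatter). The two cores on which this change is made differ in that compound 3 carries fluoro in place of methyl on an aromatic carbon relative to compound 2, a change that gave a 3.2-fold lower number from compound 2 to compound 3 (0.51 log units; beyond the scatter). Because the earlier methoxy-for-methyl step was a 1.2-fold lower number from compound 2 to compound 1 (0.07 log units; within the scatter), the step from compound 3 to compound 4 is expected to be equally small, about a 1.2-fold lower number from compound 3 to compound 4 (0.06 log units; within the scatter). Compound 4 is therefore estimated at 130 nM in this assay, with a likely range from 60 nM to 300 nM.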

Compound 4, half-maximal inhibitory concentration: 190 nM
Estimate against measurement, compound 4: 1.5-fold (0.16 log units) below; measured number inside the range.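

In this assay, methoxy in place of methyl on an aromatic carbon again moves the number little, with a 1.3-fold higher number from compound 3 to compound 4 (0.10 log units; within the scatter), and the two cores agree: the same change on two cores in this assay, a 1.2-fold lower number (0.07 log units; within the scatter) from compound 2 to compound 1 and a 1.3-fold higher number (0.10 log units; within the scatter) from compound 3 to compound 4, 1.5-fold (0.17 log units) apart, within the scatter of two such steps. Fluoro in place of methyl on an aromatic carbon carries over as well, with a 2.2-fold lower number from compound 1 to compound 4 (0.33 log units; beyond the scatter), in the same direction as on the first core: the same change on two cores in this assay, a 3.2-fold lower number (0.51 log units; beyond the scatter) from compound 2 to compound 3 and a 2.2-fold lower number (0.33 log units; beyond the scatter) from compound 1 to compound 4, 1.5-fold (0.17 log units) apart, within the scatter of two such steps. Across these four compounds, each change thus gives a similar step on both cores, but this rests on only two cores per change and does not show that it holds on any other core.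

The compounds shown leave open what an amine or a carboxylic acid would give in the place of the methoxy. They also leave open whether a longer chain in place of the ethyl on the shared core would alter these steps.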